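Shortening the propylsulfanyl chain on an active purine derivative

The source may hold more compounds than are shown below. What is called first, only, known or untested is meant among the compounds shown, and "the series" means these compounds.

Compound 1, `CCCSc1nc(N)c2nc(O)n(Cc3ccccc3)c2n1`: 0.01 uM
Compound 2, `Nc1ncnc2c1nc(O)n2Cc1cccc2ccccc12`: 10 uM
Compound 3, `Nc1ncnc2c1nc(O)n2Cc1ccc(F)cc1`: 10 uM

In a functional assay (spleen, spleen) for activation, with Mus musculus as the target (on this read-out lower numbers stand for an effect already at smaller amounts and higher numbers for an effect only at larger amounts of compound), compound 1 gives 0.01 uM, the lowest of the three numbers. Compound 2 gives 10 uM in this assay. Compound 3 gives 10 uM in this assay. Both of these stand far above compound 1, well beyond the scatter, but neither differs from compound 1 in one place only, since each lacks the propylsulfanyl group and carries a different substituent on the benzyl position. Going by the values given here, no measured pair therefore isolates the chain alone.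

Compound 4, `CSc1nc(N)c2nc(O)n(Cc3ccccc3)c2n1`, is the next compound to be tested. It differs from compound 1 as follows: hydrogen in place of ethyl on a saturated chain carbon bound to a sulfur. The shared core, the amino group, the hydroxy group and the benzyl group are all retained; only the sulfanyl chain is shortened.

With no comparison in hand for this change, the step is expected to be small, toward a somewhat higher number, of the size a 3.0-fold higher number from compound 1 to compound 4 (0.48 log units; beyond the scatter), possibly within the scatter. Compound 4 is accordingly estimated at 0.03 uM in this assay, with a range from 0.005 uM to 0.3 uM.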

Compound 4, minimum effective concentration: 0.1 uM
Compound 4: the middle estimate sits 3.3-fold (0.52 log units) below what was measured, and the stated range covers the measured number.
By their numbers in this assay, from the lowest: compound 1; then compound 4; then compounds 2 and 3 (each within the scatter of the next).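

Shortening propylsulfanyl to methylsulfanyl in this assay gives a 10-fold higher number from compound 1 to compound 4 (1.00 log units; beyond the scatter) with the rest of the structure held constant, the first measured comparison that isolates this chain. The length of the saturated chain on sulfur therefore matters in this series, and the propylsulfanyl compound has the lower number of the pair. The part exchanged is only an ethyl group of two carbons, replaced by hydrogen, with no ring or net charge involved, but nothing available explains why the shorter chain gives the higher number.

On these data alone, these chain lengths alone do not define a trend, so it remains open whether a longer chain such as butylsulfanyl, a branched isopropylsulfanyl group or an amine in place of the sulfanyl chain would give a lower or higher number. It also remains open how far the sulfanyl chain and the benzyl-position changes each contribute to the numbers of compounds 2 and 3, as no pair shown separates them.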